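A few compounds are considered here, and "the series" means these few. Any claim that something is new, unique, unknown or untested is made for them only; others in the source may bear on it.

Compound 3 `COc1cc2c(cc1OC)C(CC(=O)NC1CCCCC1)CC2` stands highest of the three measured numbers in a functional assay on the whole organism (strain Swiss albino) for inhibition, with Mus musculus as the target, in the writhing test, with stated times of 60 min and 15 min, at a dose of 100 mg/kg by the oral route (a lower number here means less inhibition, a higher number more inhibition at the dose given (going by the name of the read-out)), giving 44.7%. Compound 1 `CNC(=O)CC1CCc2cc(OC)c(OC)cc21` gives 21.2%, and compound 2 `CCN(CC)C(=O)CC1CCc2cc(OC)c(OC)cc21` gives 27.4%. One step, a number 6.2 percentage points higher from compound 1 to compound 2 (within the scatter), lies within the scatter, whereas the steps of a number 17.3 percentage points higher from compound 2 to compound 3 (beyond the scatter) and a number 23.5 percentage points higher from compound 1 to compound 3 (beyond the scatter) lie beyond it. Compound 4 `COc1cc2c(cc1OC)C(CC(=O)N1CCCC1)CC2` differs from compound 3 by pyrrolidin-1-yl in place of cyclohexylamino on a carbonyl carbon. The entering group, like the diethylamino group of compound 2, brings no hydrogen-bond donor, so the step that bears most on it is a number 17.3 percentage points higher from compound 2 to compound 3 (beyond the scatter). Run backwards, a drop of roughly that size is expected, namely a number 14.7 percentage points lower from compound 3 to compound 4 (beyond the scatter). Compound 4 is therefore expected to give about 30% in this assay, with a range from 18% to 45%.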

Compound 4, a percentage reported as inhibition, in the whole organism at one dose (the size of the read-out at that dose, not a potency): 19.2%
Estimate against measurement, compound 4: 10.8 percentage points above; the range from low to high includes it.
By their numbers in this assay, from the lowest: compounds 4, 1 and 2 (each within the scatter of the next); then compound 3.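

In this assay, a ring on the carbonyl carbon is not enough by itself to hold the number up: pyrrolidin-1-yl in place of cyclohexylamino gives a number 25.5 percentage points lower from compound 3 to compound 4 (beyond the scatter). The pyrrolidin-1-yl compound cannot be told apart from the open-chain amides, with a number 8.2 percentage points lower from compound 2 to compound 4 (within the scatter) and a number 2 percentage points lower from compound 1 to compound 4 (within the scatter). Nothing measured here explains why cyclohexylamino stands apart.

Going by these compounds, it remains open whether the cyclohexyl ring needs the amide hydrogen, since methylamino also carries that hydrogen. A piperidin-1-yl or cyclopentylamino group on the carbonyl carbon would separate ring size from the hydrogen.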